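The source may hold more compounds than are shown below. What is called first, only, known or untested is meant among the compounds shown, and "the series" means these compounds.

Of the compounds shown here, two have been tested so far in a functional assay on HeLa cells (Homo sapiens) for cytotoxicity, read by MTT assay, with a stated time of 2 days, tested at 1 uM; a higher number here means a weaker effect of the compound at the concentration tested, a lower number a stronger effect. Compound 1 `COc1ccc(-c2cc3cc(-c4ccc(F)cc4)cc(C(C)=O)c3[nH]2)cc1` gives 62.9% in this assay. Compound 2 `CC(=O)c1cc(/C=C/c2ccc(F)cc2)cc2cc(-c3ccccc3)[nH]c12` gives 70% in this assay, and this number lies within the usual scatter of that of compound 1, so the two cannot be told apart on the numbers at hand. For the measured compounds named here, no pair of measured compounds differing in a single place is available, so no measured step can be quoted.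

Compound 3 `COc1ccc(-c2cc3cc(/C=C/c4ccc(F)cc4)cc(C(C)=O)c3[nH]2)cc1` has not yet been measured. It arises from compound 2 by a single change: methoxy in place of hydrogen on an aromatic carbon. From the compounds shown here alone, the nearest guide is the pair of measured compounds, whose numbers differ in this assay by less than the scatter, but that pair does not isolate this change, so its effect remains unknown.

With nothing in the measured numbers pointing one way, compound 3 is expected to sit close to compound 2, with a step from compound 2 to compound 3 of about a number 2 percentage points lower from compound 2 to compound 3 (within the scatter), which is not beyond the scatter. On that basis compound 3 is estimated at 68% in this assay, with a range from 54% to 82%.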

Compound 3, a percentage reported as activity, at one concentration (the size of the read-out at that concentration, not a potency): 67.1%
For compound 3 the middle estimate is 0.9 percentage points above the measured one, and the stated range covers the measured number.
By their numbers in this assay, from the lowest: compounds 1, 3 and 2 (each within the scatter of the next).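

For the compounds shown here, compound 3 gives the first single-place comparisons in this assay, and both turn out small. On the six-membered aromatic ring of carbon only, para to a large group, the change from phenyl to 4-methoxyphenyl gives a number 2.9 percentage points lower from compound 2 to compound 3 (within the scatter), so methoxy in place of hydrogen at this position does not separate the two compounds at the one concentration tested. In a different place on the shared core, 2-(4-fluorophenyl)ethenyl in place of 4-fluorophenyl gives a number 4.2 percentage points higher from compound 1 to compound 3 (within the scatter), so that exchange cannot be told from the scatter either, and no measurement available here offers an explanation for either step.

From the compounds shown here alone, each change rests on a single pair, and the read-out comes from one concentration, so it remains open whether either result would hold on another background or at other concentrations. Going by these compounds, it also remains open whether an amine, a carboxylic acid or a longer alkoxy chain in place of methoxy at this position would shift the number beyond the scatter.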